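The source may hold more compounds than are shown below. What is called first, only, known or untested is meant among the compounds shown, and "the series" means these compounds.

Compound 1 `COc1c(OC)c(OC(C)=O)c2ccccc2c1OC(C)=O` gives 2.39 in a physicochemical assay for lipophilicity; on this read-out higher numbers stand for higher lipophilicity and lower numbers for lower lipophilicity. Compound 3 `COc1c(OC)c(OC(C)=O)c2c(Cl)cccc2c1OC(C)=O` differs from compound 1 by chloro in place of hydrogen on an aromatic carbon, and in this assay compound 3 gives 3.16; the step is a number 0.77 log units higher from compound 1 to compound 3 (beyond the scatter). Compound 2 `CCC(=O)Oc1c(OC)c(OC)c(OC(=O)CC)c2ccccc12` has a different core; the difference between the two cores is not broken down here. In this assay compound 2 gives 3.44, a number beyond the scatter above compound 1, while the values of compound 2 and compound 3 lie within the scatter of each other.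

Compound 4 `CCC(=O)Oc1c(OC)c(OC)c(OC(=O)CC)c2cc(Cl)ccc12` is not yet measured. It differs from compound 2 by chloro in place of hydrogen on an aromatic carbon. This is the same kind of change as that from compound 1 to compound 3, not the same: there the place is ortho to a fused ring and meta to a fused ring, here it is meta to a fused ring and para to a fused ring. The step expected from compound 2 to compound 4 is a number 0.71 log units higher from compound 2 to compound 4 (beyond the scatter), set beside the earlier one because of a number 0.77 log units higher from compound 1 to compound 3 (beyond the scatter), a single pair, so the range is kept wide. Compound 4 is expected at 4.15, between 3.75 and 4.55.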

Compound 4, partition coefficient: 4.3
For compound 4 the middle estimate is 0.15 log units below the measured one; measured number inside the range.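

In this assay, chloro in place of hydrogen on an aromatic carbon goes with a number 0.77 log units higher from compound 1 to compound 3 (beyond the scatter) and with a number 0.86 log units higher from compound 2 to compound 4 (beyond the scatter), so on these two pairs the change carries from the core of compound 1 to the core of compound 2 with the same direction. This does not separate the effect of the core from that of the place, since the chloro of compound 4 stands meta to a fused ring and para to a fused ring, a different place from that in compound 3, and two pairs make no rule for the series. Nothing at hand explains the size of either step.

Still open, on these data alone, is whether chloro in the same place on each core would give matching steps. Also open, as far as these compounds go, is whether an amine or a carboxylic acid in place of that hydrogen, or a longer chain on the core of compound 2, would move the number in the same direction.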